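Swapping the aryl group on the ring nitrogen of compound 3

The compounds below may be only part of what the source reports. "The series", "measured", "known", "first", "only" and "open" are said of these compounds alone.

Compound 3 `COc1cc2c(Oc3ccc(NC(=O)c4nn(-c5cccc(F)c5)c(=O)cc4C)cc3F)ccnc2cc1OCCCN1CCCC1` gives 120 nM in a functional assay on MKN-45 cells (Homo sapiens) for inhibition, read by MTT assay, with a stated time of 72 h; a higher number here means a weaker inhibitor, a lower number a stronger inhibitor. Among the three measured compounds it holds the second highest number: compound 2 `COc1cc2c(Oc3ccc(NC(=O)c4nn(-c5ccccc5C(F)(F)F)c(=O)cc4C)cc3F)ccnc2cc1OCCCN1CCCC1`, at 100 nM, lies within the scatter of it, while compound 1 `COc1cc2c(Oc3ccc(NC(=O)c4nn(-c5ccccc5C)c(=O)cc4C)cc3F)ccnc2cc1OCCCN1CCCC1`, at 760 nM, sits clearly higher. Compound 4 `COc1ccc(-n2nc(C(=O)Nc3ccc(Oc4ccnc5cc(OCCCN6CCCC6)c(OC)cc45)c(F)c3)c(C)cc2=O)cc1` differs from compound 3 by 4-methoxyphenyl in place of 3-fluorophenyl on an aromatic nitrogen. The measured steps that bear on this change are the two at the same aromatic nitrogen: a 6.3-fold lower number from compound 1 to compound 3 (0.80 log units; beyond the scatter) and a 1.2-fold higher number from compound 2 to compound 3 (0.08 log units; within the scatter). Within the data shown here, no measured step brings in a 4-methoxyphenyl there, so the account expects only a step of a 1.3-fold higher number from compound 3 to compound 4 (0.10 log units; within the scatter) in this assay, not beyond the scatter. Compound 4 is therefore estimated at 150 nM, within 60 nM to 400 nM.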

Compound 4, half-maximal inhibitory concentration: 1290 nM
Compound 4: the middle estimate sits 8.6-fold (0.93 log units) below what was measured; the measured number lies above the stated range.
By their numbers in this assay, from the lowest: compounds 2 and 3 (each within the scatter of the next); then compounds 1 and 4 (each within the scatter of the next).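

In this assay, among these compounds, this position proves able to carry a large change: the earlier steps here were modest at most, whereas 4-methoxyphenyl gives an 11-fold higher number from compound 3 to compound 4 (1.03 log units; beyond the scatter) and a 13-fold higher number from compound 2 to compound 4 (1.11 log units; beyond the scatter). It is not set apart from 2-methylphenyl, however, with a 1.7-fold higher number from compound 1 to compound 4 (0.23 log units; within the scatter) lying within the scatter, so the four aryl groups fall into two pairs. Nothing on hand accounts for this split. The compounds shown leave open how an unsubstituted phenyl, a pyridine ring or a simple alkyl chain on that nitrogen would read, and whether a methoxy group elsewhere on the phenyl ring would give a similar number.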